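Chloro Added, Then the Same Aryl Swap Repeated

A few compounds are considered here, and "the series" means these few. Any claim that something is new, unique, unknown or untested is made for them only; others in the source may bear on it.

Measured so far in a functional assay on CHO cells for agonist activity at adenosine receptor A1 (Homo sapiens), read by fluorescence and ERK phosphorylation, with stated times of 30 min and 1.5 h, tested at 3 uM; on this read-out lower numbers stand for a weaker effect and higher numbers for a stronger effect at the one concentration tested:
compound 1, `Nc1scc(-c2ccc(F)cc2)c1C(=O)c1ccccc1`, gives 51%;
compound 2, `Nc1scc(-c2cccc(Cl)c2)c1C(=O)c1ccccc1`, gives 45%;
compound 3, `Nc1scc(-c2ccc(F)cc2)c1C(=O)c1ccc(Cl)cc1`, gives 62%.

Compound 1 and compound 2 share one core and differ in a single place: 3-chlorophenyl in place of 4-fluorophenyl on an aromatic carbon. Across this change the read-out moves a number 6 percentage points lower from compound 1 to compound 2 (within the scatter), so the two numbers do not separate from one another.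

Compound 3 stands apart from compound 1 by a different change, (chloro in place of hydrogen on an aromatic carbon), and here the read-out moves a number 11 percentage points higher from compound 1 to compound 3 (beyond the scatter). Compound 3 thus has the highest of the three numbers, with compound 2 the furthest from it.

Compound 4, `Nc1scc(-c2cccc(Cl)c2)c1C(=O)c1ccc(Cl)cc1`, has not been measured. It relates to compound 3 in the way compound 2 relates to compound 1: 3-chlorophenyl in place of 4-fluorophenyl on an aromatic carbon. The surroundings differ slightly, since in compound 3 the place lies next to the ring atom that bears a group of 9 heavy atoms, whereas in compound 1 it lies next to the ring atom that bears a group of 8 heavy atoms; it is therefore the same kind of change rather than the same one.

The step is expected to be a number 6 percentage points lower from compound 3 to compound 4 (within the scatter), close to the earlier one, because the read-out moved only a number 6 percentage points lower from compound 1 to compound 2 (within the scatter) when the change was made on the other core. Compound 4 is therefore estimated at 56%, with a plausible span from 42% to 70%.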

Compound 4, a percentage reported as activity, at one concentration (the size of the read-out at that concentration, not a potency): 58%
The estimate for compound 4 lay 2 percentage points below the measured number, and the stated range covers the measured number.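

In this assay, the swap of 4-fluorophenyl for 3-chlorophenyl on the core of compound 3 moves the read-out a number 4 percentage points lower from compound 3 to compound 4 (within the scatter), and the step carries over from one core to the other without a separable difference: the same change on two cores in this assay, a number 6 percentage points lower (within the scatter) from compound 1 to compound 2 and a number 4 percentage points lower (within the scatter) from compound 3 to compound 4, 2 percentage points apart, within the scatter of two such steps. The chloro in place of hydrogen also keeps its size when the other aryl group is present, with the read-out moving a number 13 percentage points higher from compound 2 to compound 4 (beyond the scatter), so neither change depends measurably on the other among these four compounds, and none of them goes against this: the same change on two cores in this assay, a number 11 percentage points higher (beyond the scatter) from compound 1 to compound 3 and a number 13 percentage points higher (beyond the scatter) from compound 2 to compound 4, 2 percentage points apart, within the scatter of two such steps. This does not show that the aryl swap has a real effect on either core, since both of its steps lie within the scatter, and each comparison rests on just two pairs, read at one concentration, so it says nothing about potency or about transfer to any further core.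

The compounds shown leave open whether the same agreement would hold for a methoxy group or a carboxylic acid in place of the added chloro. They also leave open what happens to the read-out when the amino group gives way to an acetamide, or when a pyridine ring replaces the 3-chlorophenyl.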